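Lengthening a Side Chain: From Compound 3 to Compound 4

The source may report more compounds than this note shows. Statements on the series, on what has been measured and on what is new or still open speak of the compounds shown alone.

Three compounds have been measured in a functional assay on the whole organism for inhibition, with Chlorella vulgaris as the target, read by spectrophotometry, with a stated time of 4 h; a higher number here means a weaker inhibitor, a lower number a stronger inhibitor:
compound 1 `CC(C)(C)c1cnc(C(=O)Nc2cccc(O)c2)cn1` gives 329000 nM
compound 2 `CC(C)(C)c1ncc(C(=O)Nc2cc(O)cc(Cl)c2)nc1Cl` gives 99000 nM
compound 3 `CC(C)c1cnc(C(=O)/C=C/c2ccccc2O)cn1` gives 78000 nM

Compound 3 has the lowest of the three numbers in this assay. Its gap to compound 2 is within the scatter of repeated measurements, so the two cannot be told apart on these data, while its gap to compound 1 is beyond the scatter, so compound 3 is a clearly stronger inhibitor than compound 1. None of the three pairs differ in only one place, so no single structural step can be read off from them.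

Compound 4 `CC(C)Cc1cnc(C(=O)/C=C/c2ccccc2O)cn1` has not yet been measured. It differs from compound 3 in one place: isobutyl in place of isopropyl on an aromatic carbon. The chain grows by one carbon and keeps no donors or acceptors, and the rest of the molecule is unchanged. Going by the values given here, nothing among the measured compounds shows what such a change does in this assay. The expectation is therefore a step from compound 3 to compound 4 of a 1.1-fold lower number from compound 3 to compound 4 (0.05 log units; within the scatter), in no direction beyond the scatter. Compound 4 is estimated at 70000 nM, with a range from 25000 nM to 200000 nM.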

Compound 4, half-maximal inhibitory concentration: 63000 nM
Compound 4: the middle estimate sits 1.1-fold (0.05 log units) above what was measured; low and high end bracket the measured number.
By their numbers in this assay, from the lowest: compounds 4, 3 and 2 (each within the scatter of the next); then compound 1.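

In this assay, going by these compounds alone, the exchange of isopropyl for isobutyl gives a 1.2-fold lower number from compound 3 to compound 4 (0.09 log units; within the scatter) and is the first step in this set that changes only one place, so it offers the first direct reading of this position, an aromatic carbon next to the ring nitrogen and para to a large group. Isobutyl, with 4 heavy atoms against the 3 of isopropyl, leaves the result indistinguishable from that of the shorter group, so this particular lengthening of the side chain has no effect that these data can resolve. No measurement is available that would explain this result.

The compounds shown leave open whether a much longer chain such as hexyl, or a chain ending in an amine or a carboxylic acid, would move the number at this position beyond the scatter. They also leave open whether a phenyl group here would be accommodated as readily as isobutyl, and whether the same exchange would give a similar result on an amide such as compound 1.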